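Swapping 1-hydroxyethyl for cyano on a shared core

A few compounds are considered here, and "the series" means these few. Any claim that something is new, unique, unknown or untested is made for them only; others in the source may bear on it.

Three measured compounds share one core and differ in a single group on an aromatic carbon. In an ADME assay on microsomes from liver (Mus musculus) for metabolic stability, read by LC-MS, using NADPH, with stated times of 6 min and 10 min, tested at 0.5 uM (a lower number here means that less of the compound is left, a higher number that more of the compound is left), compound 1 `CC(=O)N1CCN(c2cc(-c3cc(Cl)c4c(N)ncnn34)ccc2C(F)(F)F)C(=O)C1(C)C` gives 88%, compound 2 `CC(=O)N1CCN(c2cc(-c3cc(Cl)c4c(N)ncnn34)ccc2Cl)C(=O)C1(C)C` gives 67%, and compound 3 `CC(=O)N1CCN(c2cc(-c3cc(Cl)c4c(N)ncnn34)ccc2C(C)O)C(=O)C1(C)C` gives 100%, the highest of the three numbers.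

Compound 4 `CC(=O)N1CCN(c2cc(-c3cc(Cl)c4c(N)ncnn34)ccc2C#N)C(=O)C1(C)C` has not been measured yet. It carries cyano in place of 1-hydroxyethyl on an aromatic carbon.

Going by the values given here, no measured step makes this exact swap, so the nearest evidence comes from the other groups at that place. Putting 1-hydroxyethyl in place of chloro gave a number 33 percentage points higher from compound 2 to compound 3 (beyond the scatter), and putting it in place of trifluoromethyl gave a number 12 percentage points higher from compound 1 to compound 3 (beyond the scatter). Chloro in place of trifluoromethyl gave a number 21 percentage points lower from compound 1 to compound 2 (beyond the scatter). Both groups that stand in for 1-hydroxyethyl so far give lower numbers, though these are only two cases.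

A modest step down is therefore expected, an estimated a number 18 percentage points lower from compound 3 to compound 4 (beyond the scatter). The estimated value for compound 4 is 82%, with an expected range from 60% to 98%.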

Compound 4, percent of the compound remaining: 89%
Beside the measured number, compound 4's estimate is 7 percentage points below it; measured number inside the range.
By their numbers in this assay, from the lowest: compound 2; then compounds 1 and 4 (each within the scatter of the next); then compound 3.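

In this assay, cyano is a third group standing in for 1-hydroxyethyl at this place, and it gives a number 11 percentage points lower from compound 3 to compound 4 (beyond the scatter) and so leaves 1-hydroxyethyl with the highest number of the four groups shown. Cyano also gives a number 22 percentage points higher from compound 2 to compound 4 (beyond the scatter) and thus recovers most of what chloro loses, while a number 1 percentage points higher from compound 1 to compound 4 (within the scatter) shows that cyano and trifluoromethyl cannot be told apart here, so two different groups on this aromatic carbon end up level. Nothing shown explains why these groups rank as they do.

From the compounds shown here alone, whether a methoxy group, an amine or a carboxylic acid on this carbon would match 1-hydroxyethyl remains open. Going by these compounds, it is also open whether this order of groups would hold on any core other than the shared one.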